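Mirror Images and Inverted Centres in a Sugar-Enzyme Compound Series

The compounds below may be only part of what the source reports. "The series", "measured", "known", "first", "only" and "open" are said of these compounds alone.

In an assay on isolated protein for inhibition of cytosolic endo-beta-N-acetylglucosaminidase (Homo sapiens), tested at 1000 uM (on this read-out lower numbers stand for less inhibition and higher numbers for more inhibition at the one concentration tested (going by the name of the read-out)), three compounds have been measured. Compound 1, `O=C(O)[C@H]1NCC=C[C@@H]1O`, gives 60% in this assay. Compound 3, `O=C(O)[C@@H]1NCC=C[C@H]1O`, gives 14%. The step of a number 46 percentage points lower from compound 1 to compound 3 (beyond the scatter) rests on nothing but configuration, since (the fact that compounds 1 and 3 differ only in the configuration as drawn), which shows that the drawn arrangement alone can move the read-out a long way. Compound 2, `O=C(O)[C@@H]1NC[C@H](O)[C@@H](O)[C@@H]1O`, gives 5.4% and stands lowest of the three numbers; its nearest neighbour is compound 3, which lies within the scatter of it, and its furthest is compound 1, which lies beyond the scatter above it.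

Compound 4 is `O=C(O)[C@H]1NC[C@H](O)[C@H](O)[C@@H]1O`. Compared with compound 2, (the two compounds have the same atoms and bonds and differ only in configuration as drawn: 2 of 4 stereo elements differ; a stereocentre at a saturated ring carbon is drawn R in compound 2 and S in compound 4; a stereocentre at a saturated ring carbon is drawn R in compound 2 and S in compound 4). For the measured compounds named here, the only measured step that bears on such a change is the inversion from compound 1 to compound 3, which was large. Compound 4 inverts two of four centres rather than all, so a step of some size in this assay is expected, and because compound 2 sits at 5.4% there is more room upward than downward. The expected step is a number 19.6 percentage points higher from compound 2 to compound 4 (beyond the scatter). Compound 4 is therefore estimated at 25%, with a range from 2% to 65%.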

Compound 4, a percentage reported as inhibition, at one concentration (the size of the read-out at that concentration, not a potency): 26%
Estimate against measurement, compound 4: 1 percentage points below; low and high end bracket the measured number.
By their numbers in this assay, from the lowest: compounds 2 and 3 (each within the scatter of the next); then compound 4; then compound 1.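

The earlier inversion changed every stereocentre, so that pair were mirror images; here only part of the centres change, and in this assay the result is still a number 20.6 percentage points higher from compound 2 to compound 4 (beyond the scatter). A complete mirror image is therefore not needed for a shift beyond the scatter, and the effect of drawn configuration is not confined to the pair seen first. The shift can be put down to configuration alone because no atom or bond separates the two compounds: the fact that compounds 2 and 4 differ only in the configuration as drawn.

The two inverted centres change together, so the compounds shown cannot tell whether one of them alone carries the step or both contribute to it. Also open, going by these compounds, is how the read-out would respond if the carboxylic acid of compound 4 were replaced by a methyl ester or an amide while its configuration stayed the same, which would test whether the arrangement seen here still counts once that group is gone.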